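The source may hold more compounds than are shown below. What is called first, only, known or untested is meant among the compounds shown, and "the series" means these compounds.

Working notes on the series. In a functional assay on HepG2 cells (Homo sapiens) for cytotoxicity, read by sulforhodamine B assay, with a stated time of 48 h (on this read-out lower numbers stand for stronger inhibition and higher numbers for weaker inhibition), compound 1 `CCc1ccc(Nc2nn3c(-c4ccc([N+](=O)[O-])o4)nnc3s2)cc1` gives 3.78 ug/mL and compound 2 `O=[N+]([O-])c1ccc(-c2nnc3sc(Nc4ccc(F)cc4)nn23)o1` gives 11.3 ug/mL. Within the data shown here, of the two numbers seen so far, compound 2 carries the higher one, which on this read-out stands for weaker inhibition; the single measured step, a 3.0-fold higher number from compound 1 to compound 2 (0.48 log units; beyond the scatter), is modest but beyond the scatter and goes with fluoro in place of ethyl on an aromatic carbon.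

Compound 3 `O=[N+]([O-])c1ccc(-c2nnc3sc(Nc4ccccc4)nn23)o1` differs from compound 2 by hydrogen in place of fluoro on an aromatic carbon of a six-membered aromatic ring of carbon only, para to a large group; read one bond further out, 4-fluorophenyl becomes phenyl. Among the measured compounds shown here, no measured step isolates fluoro against hydrogen. For the measured compounds named here, the only step at hand, a 3.0-fold higher number from compound 1 to compound 2 (0.48 log units; beyond the scatter), trades a larger group for fluoro at that position and raised the number; it offers weak guidance for removing fluoro altogether. The change in compound 3 is therefore expected to be small, with no clear direction beyond the scatter, a 1.3-fold lower number from compound 2 to compound 3 (0.10 log units; within the scatter). For compound 3 in this assay the expected value is 9 ug/mL, within a range from 4.5 ug/mL to 20 ug/mL.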

Compound 3, half-maximal inhibitory concentration: 4.23 ug/mL
The estimate for compound 3 lay 2.1-fold (0.33 log units) above the measured number; the measured number lies below the stated range.
By their numbers in this assay, from the lowest: compounds 1 and 3 (each within the scatter of the next); then compound 2.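

In this assay, the step from the 4-fluorophenyl to the phenyl compound is a 2.7-fold lower number from compound 2 to compound 3 (0.43 log units; beyond the scatter) and lies beyond the scatter, so fluoro on this aromatic carbon, para to a large group, does carry a measurable cost against plain hydrogen. Ethyl and hydrogen at the same place cannot be told apart, with a 1.1-fold higher number from compound 1 to compound 3 (0.05 log units; within the scatter) inside the scatter, so the earlier step from ethyl to fluoro now reads as a rise in the number that goes with fluoro, not as a loss that goes with removing ethyl. Among the three compounds, compound 2 alone stands apart, while compound 1 and compound 3 give the same result within the scatter, and nothing at hand explains why fluoro behaves differently here.

Going by these compounds, it remains open whether chloro, methoxy, an amine or a carboxylic acid at this place would side with hydrogen and ethyl or with fluoro. A longer chain such as butyl would show whether the match between ethyl and hydrogen holds as the group grows, and one fluoro compound cannot say whether its higher number extends to any other group.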